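The source may hold more compounds than are shown below. What is called first, only, known or untested is meant among the compounds shown, and "the series" means these compounds.

Compound 1 `Cc1cc(NCCCc2ccccn2)n2nc(C)c(-c3ccccc3)c2n1` gives 5900 nM in a physicochemical assay for solubility, read by HPLC, using the shake flask method, measured as kinetic solubility, with a stated time of 2 h, at pH 7.4; a higher number here means a more soluble compound, a lower number a less soluble compound.
Compound 2 `Cc1cc(NCc2cccs2)n2nc(C)c(-c3ccccc3)c2n1` gives only a limit in this assay, recorded as < 5000 nM.
Compound 3 `Cc1cc(NCc2nccs2)n2nc(C)c(-c3ccccc3)c2n1` gives 108000 nM in this assay.

Among the numbers shown, compound 3 stands highest: the step of an 18-fold higher number from compound 1 to compound 3 (1.26 log units; beyond the scatter) is large, and the step of an at least 21-fold higher number from compound 2 to compound 3 (1.33 log units; beyond the scatter) is at least as large, resting on (the limit of < 5000 nM in this assay, at which 1 of the 3 values shown sits). By contrast, the step of an at least 1.1-fold lower number from compound 1 to compound 2 (0.07 log units; that floor lies within the scatter) stays within the scatter.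

Compound 4 `Cc1cc(NCc2ccc(F)cn2)n2nc(C)c(-c3ccccc3)c2n1` differs from compound 3 in one place: 5-fluoropyridin-2-yl in place of 1,3-thiazol-2-yl on a saturated chain carbon bound to a nitrogen on an aromatic ring. For the measured compounds named here, two measured steps bear on this change. Both of them show the thiazole ring of compound 3 sitting far above the two other groups tried at the same position, one of which, in compound 1, is itself a pyridine ring on a longer chain. Moving from compound 3 to a pyridine ring therefore points toward a lower number, and the expected drop is a 5.4-fold lower number from compound 3 to compound 4 (0.73 log units; beyond the scatter). Compound 4 is thus estimated at 20000 nM in this assay, with a range from 4000 nM to 100000 nM.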

Compound 4, solubility: < 5000 nM
Compound 4: a limit, no number (the forecaster's own chance of this, stated with the estimate: 20%); middle value at least 4.0-fold (0.60 log units) away from the limit.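

In this assay, compound 4 gives a limit, not a number. Even so, the step is clear: an at least 21-fold lower number from compound 3 to compound 4 (1.33 log units; beyond the scatter). Compound 3 now stands apart from both the thiophen-2-yl and the 5-fluoropyridin-2-yl groups at this place, so swapping one aromatic ring for another here is not a neutral change, and among the compounds shown only the 1,3-thiazol-2-yl group gives a high reading. The other comparisons say less, with an at least 1.1-fold lower number from compound 1 to compound 4 (0.07 log units; that floor lies within the scatter) having a floor within the scatter, and the step between compound 2 and compound 4 cannot be read since both are limits: the limit of < 5000 nM in this assay, at which 2 of the 4 values shown sit.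

Whether the fluorine plays any part stays open, since a plain pyridin-2-yl group on the same chain carbon is not among the compounds shown. Also open, on these data alone, is whether a 1,3-oxazol-2-yl group, or a thiazole ring carrying an amine, would match compound 3.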